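Halogen swap on the naphthyl ring and cytotoxicity

This account rests on a few compounds, and the source may have more. Where it says the series, first, only, none or still open, it means among the compounds named here.

The series shares one core, seen in compound 1 `Cc1cc(S(N)(=O)=O)ccc1NC(=O)COc1ccc(F)cc1Oc1ccc2ccccc2c1`, and is followed in an ADME assay on C8166 cells (Homo sapiens) for cytotoxicity, read by MTT assay; a lower number here means that less compound is tolerated, a higher number that more compound is tolerated. Compound 1 gives 68600 nM. Compound 2 `Cc1cc(S(N)(=O)=O)ccc1NC(=O)COc1ccc(F)cc1Oc1ccc2cc(Br)ccc2c1` carries bromo in place of hydrogen on an aromatic carbon. In this assay compound 2 reaches only a limit, > 357000 nM, so no number is known for it. The step from compound 1 to compound 2 is therefore an at least 5.2-fold higher number from compound 1 to compound 2 (0.71 log units; beyond the scatter), and it rests on the limit of > 357000 nM in this assay, at which 1 of the 2 values shown sits, rather than on a measured number for compound 2.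

Compound 3 `Cc1cc(S(N)(=O)=O)ccc1NC(=O)COc1ccc(F)cc1Oc1ccc2ccccc2c1Cl` is not yet measured. It differs from compound 2 in that (1-chloronaphthalen-2-yl in place of 6-bromonaphthalen-2-yl on an oxygen on an aromatic ring). Going by the values given here, only the one measured step bears on this change: a halogen entering the naphthyl ring moved the number beyond the scatter in compound 2, but here the halogen changes and moves to another carbon of the same ring, so the hydrogen-bearing compound 1 is as relevant a reference as compound 2. For compound 3 a value is expected to lie between those two references, and the step of an at least 2.3-fold lower number from compound 2 to compound 3 (0.37 log units; beyond the scatter) is the estimated consequence. Compound 3 is thus estimated at 150000 nM, within 50000 nM to 400000 nM.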

Compound 3, half-maximal cytotoxic concentration: 47100 nM
Beside the measured number, compound 3's estimate is 3.2-fold (0.50 log units) above it; the whole stated range lies above it.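

In this assay, chloro in place of hydrogen gives a 1.5-fold lower number from compound 1 to compound 3 (0.16 log units; within the scatter), so a halogen on this ring does not by itself bring the rise seen with compound 2. The change from 6-bromonaphthalen-2-yl to 1-chloronaphthalen-2-yl on the oxygen gives an at least 7.5-fold lower number from compound 2 to compound 3 (0.87 log units; beyond the scatter), which shows that the two halogen-bearing groups are not interchangeable in this assay. Compound 2 stands only at a limit, > 357000 nM, so the size of that step remains a bound and not a measured difference: the limit of > 357000 nM in this assay, at which 1 of the 3 values shown sits.

The halogen and its carbon change together in this step, and the compounds shown do not separate the two; chloro on the carbon that bears bromo in compound 2, or bromo on the carbon that bears chloro in compound 3, would do so. Also open, going by these compounds, is how this assay would read with an amine or a methoxy group on either of these carbons, and so whether the step belongs to halogens alone.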